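Ring for Chain at One End of Compound 2

The compounds below may be only part of what the source reports. "The series", "measured", "known", "first", "only" and "open" are said of these compounds alone.

Compound 1 `CC(C)OC(=O)c1cccc(O)c1C(=O)c1c(O)cc(C(=O)O[C@@H]2CCC[C@H]2NC(=O)c2ccc(O)cc2)cc1O` gives 13000 nM in an in vitro assay on Sf-9 cells for inhibition of protein kinase C epsilon type (Homo sapiens); on this read-out higher numbers stand for weaker inhibition and lower numbers for stronger inhibition.
Compound 2 `CCCCOC(=O)c1cccc(O)c1C(=O)c1c(O)cc(C(=O)O[C@@H]2CNC[C@H]2NC(=O)c2ccc(O)cc2)cc1O` gives 3700 nM in this assay.

Of these two measured compounds, compound 2 stands at the lower number, and its distance from compound 1 lies beyond the usual scatter of this assay. Compound 3 `O=C(N[C@@H]1CNC[C@H]1OC(=O)c1cc(O)c(C(=O)c2c(O)cccc2C(=O)OCC2CCCCC2)c(O)c1)c1ccc(O)cc1` has not yet been measured. It differs from compound 2 in a single spot: cyclohexyl in place of propyl on a saturated chain carbon bound to an oxygen next to a carbonyl group. Going by the values given here, no measured pair shows this same exchange, so there is no step between known compounds to lean on, and the direction of the change cannot be read from the data. The expectation is therefore a small step of a 1.2-fold lower number from compound 2 to compound 3 (0.09 log units; within the scatter) in this assay, one that may well fall within the scatter, with a wide range to either side. On that basis compound 3 is estimated at 3000 nM, with a range from 1000 nM to 10000 nM.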

Compound 3, half-maximal inhibitory concentration: 25000 nM
Estimate against measurement, compound 3: 8.3-fold (0.92 log units) below, outside the stated range (above it).
By their numbers in this assay, from the lowest: compound 2; then compounds 1 and 3 (each within the scatter of the next).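

In this assay, putting cyclohexyl in place of propyl on a saturated chain carbon bound to an oxygen next to a carbonyl group gives a 6.8-fold higher number from compound 2 to compound 3 (0.83 log units; beyond the scatter). Going by these compounds alone, this is the first direct sign that the far end of this chain is not a free spot: in this pair, exchanging the open chain end for a ring of carbon goes with weaker inhibition. Nothing at hand explains why the number rises.

The pair changes two things at once, the presence of a ring and the number of carbons, so it cannot say which of them matters, and a straight hexyl chain in the same place would pull the two apart. As far as these compounds go, how a shorter ethyl group or a chain ending in an amine would fare here also remains open.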